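Methoxy removal on aryl ester cinnamates: cytotoxicity notes

The source may hold more compounds than are shown below. What is called first, only, known or untested is meant among the compounds shown, and "the series" means these compounds.

Measured compounds in a functional assay on EA.hy 926 cells (Homo sapiens) for cytotoxicity, read by MTT assay, with stated times of 24 h and 12 h; on this read-out higher numbers stand for an effect only at larger amounts of compound and lower numbers for an effect already at smaller amounts:
compound 1 `Cc1nc(C)c(C(=O)Oc2ccccc2/C=C/C(=O)O)nc1C` gives 36700 nM
compound 2 `COc1ccc(/C=C/C(=O)O)c(OC(=O)c2nc(C)c(C)nc2C)c1` gives 115000 nM
compound 3 `CCOC(=O)/C=C/c1cc(OC)c(OC(=O)c2nc(C)c(C)nc2C)c(OC)c1` gives 21400 nM

Compound 3 has the lowest number of the three; its gap to compound 1 lies within the scatter, its gap to compound 2 beyond it. The difference between the core of compound 2 and the core of compound 3 is not broken down here.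

One change is seen once: hydrogen in place of methoxy on an aromatic carbon gives a 3.1-fold lower number from compound 2 to compound 1 (0.50 log units; beyond the scatter). The not yet measured compound 4 `CCOC(=O)/C=C/c1ccc(OC(=O)c2nc(C)c(C)nc2C)c(OC)c1` carries the same kind of change on compound 3: hydrogen in place of methoxy on an aromatic carbon. The surroundings differ: in compound 2 the methoxy sits meta to a large group and para to a 2-carboxyethenyl group, in compound 3 ortho to a large group and meta to a 2-(ethoxycarbonyl)ethenyl group and meta to a methoxy group. A step of a 1.5-fold lower number from compound 3 to compound 4 (0.18 log units; within the scatter) is expected for compound 4 in this assay, resting on one observed step only. Compound 4 is expected to give about 14000 nM, between 5000 nM and 40000 nM.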

Compound 4, half-maximal effective concentration: 38600 nM
For compound 4 the middle estimate is 2.8-fold (0.44 log units) below the measured one; low and high end bracket the measured number.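

In this assay, hydrogen in place of methoxy on an aromatic carbon gives a 1.8-fold higher number from compound 3 to compound 4 (0.26 log units; within the scatter), so the step seen on the earlier core does not carry over to the core of compound 3. The two steps differ: the same change on two cores in this assay, a 3.1-fold lower number (0.50 log units; beyond the scatter) from compound 2 to compound 1 and a 1.8-fold higher number (0.26 log units; within the scatter) from compound 3 to compound 4, 5.7-fold (0.75 log units) apart, beyond the scatter of two such steps

With a single step on each core, the data do not show which difference between the cores sets the two steps apart, nor how this change would behave on any further core. The compounds shown leave open what an amine or a longer alkoxy chain in place of the methoxy would give on either core. They also leave open whether the remaining methoxy group of compound 4 can be replaced in the same way.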